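Series notes: phenyl replacing ethoxycarbonyl at compound 4

The compounds below may be only part of what the source reports. "The series", "measured", "known", "first", "only" and "open" are said of these compounds alone.

Three compounds of the series have numbers in a functional assay on PC-12 cells (Rattus norvegicus) for cytotoxicity, read by MTT assay, with stated times of 3 h and 2 h, tested at 50 uM; a lower number here means a weaker effect, a higher number a stronger effect of the compound at the concentration tested. Compound 1 `Cc1cc(=O)oc2cc(OCCCn3cc(CNC(=O)CCCCC4CCSS4)nn3)ccc12` gives 75.4%, compound 2 `CC(=O)c1cc2ccc(OCCCn3cc(CNC(=O)CCCCC4CCSS4)nn3)cc2oc1=O` gives 40.7%, and compound 3 `CCOC(=O)c1cc2ccc(OCCCn3cc(CNC(=O)CCCCC4CCSS4)nn3)cc2oc1=O` gives 49.2%. On these numbers compound 3 stands second of three; its nearest neighbour is compound 2, whose gap to it is within the scatter, and the furthest is compound 1, which lies beyond the scatter higher. For the measured compounds named here, the only step between compounds differing in one place, a number 8.5 percentage points higher from compound 2 to compound 3 (within the scatter), is within the scatter.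

Compound 4 `O=C(CCCCC1CCSS1)NCc1cn(CCCOc2ccc3cc(-c4ccccc4)c(=O)oc3c2)nn1` differs from compound 3 as follows: phenyl in place of ethoxycarbonyl on an aromatic carbon. Going by the values given here, no measured step exchanges a carbonyl-bearing group for an aromatic ring at this place; the one measured step, ethoxy for methyl on a carbonyl carbon, changed little. The gap from compound 1 to compound 2 or compound 3 involves a different group at a different place and is not a single-point step. For compound 4 in this assay no step beyond the scatter is expected, a number 0.8 percentage points higher from compound 3 to compound 4 (within the scatter). The estimate for compound 4 is 50%, with a range from 28% to 72%.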

Compound 4, a percentage reported as activity, at one concentration (the size of the read-out at that concentration, not a potency): 23.1%
For compound 4 the middle estimate is 26.9 percentage points above the measured one; measured number outside the range, below it.
By their numbers in this assay, from the lowest: compound 4; then compounds 2 and 3 (each within the scatter of the next); then compound 1.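

In this assay, phenyl in place of ethoxycarbonyl gives a number 26.1 percentage points lower from compound 3 to compound 4 (beyond the scatter), and phenyl in place of acetyl gives a number 17.6 percentage points lower from compound 2 to compound 4 (beyond the scatter). This aromatic carbon, two atoms from the ring oxygen, is therefore not indifferent to its substituent: ethoxy in place of methyl on the carbonyl carbon stays within the scatter, whereas replacing either carbonyl-bearing group with a six-membered aromatic ring of carbon only goes beyond it. No measurement on these compounds bears on the cause of this shift.

Going by these compounds, whether the ring itself or the absence of a carbonyl at this place sets the lower number remains open. A carboxylic acid, a primary amide, a methyl group or a pyridyl ring on this carbon would help separate those two readings.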